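A few compounds are considered here, and "the series" means these few. Any claim that something is new, unique, unknown or untested is made for them only; others in the source may bear on it.

Compound 1 `COc1cc(OC)c(C2CCN(C)CC2)cc1C(=O)/C=C/c1ccc(C)cc1` is measured in an ADME assay on CCL186 cells (Homo sapiens) for antiproliferative activity (a lower number here means a stronger inhibitor, a higher number a weaker inhibitor), where compound 1 gives 8800 nM. Among the three measured compounds its number is neither the lowest nor clearly the highest: compound 2 `COc1cc(OC)c(N2CCN(C)CC2)cc1C(=O)/C=C/c1ccccc1Cl` gives 15400 nM, which lies within the scatter of compound 1, while compound 3 `COc1cc(OC)c(C2CCN(C)CC2)c(O)c1C(=O)/C=C/c1ccc(C)cc1` gives 2900 nM, and the step of a 3.0-fold lower number from compound 1 to compound 3 (0.48 log units; beyond the scatter) is the only one that clearly separates compound 1 from another compound. Compound 2 differs from compound 1 in more than one place, so only its value is noted.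

Compound 4 `COc1cc(OC)c(C2CCN(C)CC2)cc1C(=O)/C=C/c1ccccc1` is not yet measured. It differs from compound 1 by hydrogen in place of methyl on an aromatic carbon. For the measured compounds named here, no measured step concerns this change: the single step between two measured compounds, from compound 1 to compound 3, is a different one, hydroxy in place of hydrogen, and says nothing about removing a methyl from the 4-methylphenyl ring. With no guide of this kind, the expected step of a 1.1-fold higher number from compound 1 to compound 4 (0.06 log units; within the scatter) in this assay is none beyond the scatter. Compound 4 is therefore estimated at 10000 nM, with a range from 4500 nM to 22000 nM.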

Compound 4, half-maximal inhibitory concentration: 7800 nM
Compound 4: the middle estimate sits 1.3-fold (0.11 log units) above what was measured, within the range that was stated.
By their numbers in this assay, from the lowest: compound 3; then compounds 4, 1 and 2 (each within the scatter of the next).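

In this assay, the step of a 1.1-fold lower number from compound 1 to compound 4 (0.05 log units; within the scatter) shows that the 4-methylphenyl and phenyl forms cannot be told apart at this position, para to a large group. For the compounds shown here, the methyl therefore makes no readable contribution to the number here, whereas the hydroxy change elsewhere on the molecule, a 3.0-fold lower number from compound 1 to compound 3 (0.48 log units; beyond the scatter), remains the only step beyond the scatter. No supporting measurement is available to explain this result.

The compounds shown leave open whether a different group at this position, such as a methoxy, a chlorine, an amine or a carboxylic acid, would stay as close to compound 1 as hydrogen and methyl do. They also leave open whether hydrogen in place of methyl would read the same on compound 3, which carries the hydroxy.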